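Phenyl for Methyl on a Ring Amide Nitrogen

The compounds below may be only part of what the source reports. "The series", "measured", "known", "first", "only" and "open" are said of these compounds alone.

Measured so far:
Compound 1, `CC(C)[C@@H]1CC[C@@H](C)C[C@@]12N(C)C(=O)[C@@H]1[C@H]3C(=O)NC(=O)[C@H]3ON12`, gives 67.2% in a functional assay, with a stated time of 20 min, tested at 2.5 mg/mL; a lower number here means a weaker effect, a higher number a stronger effect of the compound at the concentration tested.
Compound 2, `CC(C)[C@@H]1CC[C@@H](C)C[C@@]12N(C)C(=O)[C@@H]1[C@H]3C(=O)N(C)C(=O)[C@H]3ON12`, gives 55.8% in this assay.

For the measured compounds named here, of the two numbers known, compound 2 holds the lower one, and its nearest neighbour is compound 1, whose value stands above it beyond the scatter. The step of a number 11.4 percentage points lower from compound 1 to compound 2 (beyond the scatter) is the only measured one, and it describes a methyl in place of hydrogen on an amide-type nitrogen in a ring. Compound 3, `CC(C)[C@@H]1CC[C@@H](C)C[C@@]12N(C)C(=O)[C@@H]1[C@H]3C(=O)N(c4ccccc4)C(=O)[C@H]3ON12`, is not yet measured. It differs from compound 2 as follows: phenyl in place of methyl on an amide-type nitrogen in a ring. Going by the values given here, no measured step covers a phenyl in place of methyl at this position, so the single known step offers only weak guidance, and no step beyond the scatter is firmly expected. Compound 3 is therefore estimated at 50%, between 28% and 72%, which would mean an expected step of a number 5.8 percentage points lower from compound 2 to compound 3 (within the scatter).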

Compound 3, a percentage reported as activity, at one concentration (the size of the read-out at that concentration, not a potency): 76.2%
The estimate for compound 3 lay 26.2 percentage points below the measured number, and the stated range ends below it.
By their numbers in this assay, from the lowest: compound 2; then compounds 1 and 3 (each within the scatter of the next).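

In this assay, a substituent on this amide-type nitrogen does not always go with a lower read-out: the methyl step had been downward, yet phenyl in place of methyl gives a number 20.4 percentage points higher from compound 2 to compound 3 (beyond the scatter) on the shared core. Phenyl in place of the amide hydrogen gives a number 9 percentage points higher from compound 1 to compound 3 (within the scatter), so this read-out cannot separate phenyl from hydrogen at this position, and only methyl stands apart beyond the scatter. No available evidence bears on why methyl and phenyl part ways on this nitrogen.

As far as these compounds go, what a benzyl group, a pyridine ring or a longer alkyl chain would do on the same nitrogen stays open. So does whether a substituted phenyl, for example one carrying a methoxy group or a chlorine atom, would follow phenyl or methyl.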